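Methyl on the distal phenyl of compound 2

The compounds below may be only part of what the source reports. "The series", "measured", "known", "first", "only" and "open" are said of these compounds alone.

Measured so far:
compound 1, `O=C(NC1CCCC1)c1ccc(C#Cc2cccnc2)nc1`: > 10000 nM
compound 2, `O=C1c2ccc(C#Cc3ccccc3)nc2CCN1C1CCCC1`: 5.9 nM

In a functional assay on HEK293 cells for positive allosteric modulation of metabotropic glutamate receptor 5 (Homo sapiens), read by FLIPR and calcium flux (a lower number here means that less compound is needed, a higher number that more compound is needed for the effect), compound 1 gives > 10000 nM, which is a limit of the assay and not a number (the limit of > 10000 nM in this assay, at which 1 of the 2 values shown sits). In this assay, among the measured compounds shown here, compound 2 gives 5.9 nM, the only number in hand. Compound 3, `Cc1cccc(C#Cc2ccc3c(n2)CCN(C2CCCC2)C3=O)c1`, differs from compound 2 by methyl in place of hydrogen on an aromatic carbon. No step between measured compounds is shown, so nothing sets the size of this one; a change no larger than the scatter, in either direction, is expected. For compound 3 the expected value is 4.5 nM, between 1.5 nM and 15 nM. The expected step is a 1.3-fold lower number from compound 2 to compound 3 (0.12 log units; within the scatter).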

Compound 3, half-maximal effective concentration: 7.5 nM
Estimate against measurement, compound 3: 1.7-fold (0.22 log units) below; the range from low to high includes it.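

In this assay, among the compounds shown here, phenyl to 3-methylphenyl gives a 1.3-fold higher number from compound 2 to compound 3 (0.10 log units; within the scatter) and so shows the first reading at this place: a methyl on an aromatic carbon, meta to a large group, is tolerated. This one pair says nothing yet about any other group here. Nothing measured bears on why the number holds. Open, going by these compounds, is whether a chlorine, a methoxy or a nitrile at the same place behaves like methyl. Also open, on these data alone, is whether a carboxylic acid or an amine on this ring holds the number.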